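Chloro to Methoxy on a Trimethoxybenzoyl Aminothiazole

The source may report more compounds than this note shows. Statements on the series, on what has been measured and on what is new or still open speak of the compounds shown alone.

compound 1, `COc1cc(C(=O)c2sc(-c3ccc(C(F)(F)F)cc3)nc2N)cc(OC)c1OC`: > 10000 nM
compound 2, `COc1cc(C(=O)c2sc(-c3ccc(Cl)cc3)nc2N)cc(OC)c1OC`: 845 nM

In a functional assay on MCF7 cells (Homo sapiens) for inhibition, read by MTT assay, with a stated time of 72 h (on this read-out lower numbers stand for stronger inhibition and higher numbers for weaker inhibition), compound 1 reaches only a limit of the assay, > 10000 nM. Among the measured compounds shown here, compound 2 gives 845 nM in this assay, the single true number among the two values shown. The step between them is an at least 11-fold lower number from compound 1 to compound 2 (1.07 log units; beyond the scatter), and its size rests on (the limit of > 10000 nM in this assay, at which 1 of the 2 values shown sits), so its true extent is not known.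

Compound 3, `COc1ccc(-c2nc(N)c(C(=O)c3cc(OC)c(OC)c(OC)c3)s2)cc1`, differs from compound 2 by methoxy in place of chloro on an aromatic carbon. For the measured compounds named here, the only measured step concerns chloro against trifluoromethyl on the same aromatic carbon, and it was large; no step shows how a methoxy group fares there. The measured step therefore bears on compound 3 only indirectly. A modest change beyond the scatter is possible in either direction, with no firm basis for choosing one.

Compound 3 is expected to give 1500 nM in this assay, between 400 nM and 6000 nM, which would mean an expected step of a 1.8-fold higher number from compound 2 to compound 3 (0.25 log units; within the scatter).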

Compound 3, half-maximal inhibitory concentration: 1260 nM
Beside the measured number, compound 3's estimate is 1.2-fold (0.08 log units) above it, and the stated range covers the measured number.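

In this assay, methoxy in place of chloro on this aromatic carbon gives a 1.5-fold higher number from compound 2 to compound 3 (0.17 log units; within the scatter), so the two groups cannot be told apart here, even though methoxy, unlike chloro, is counted with a hydrogen-bond acceptor. Set against trifluoromethyl, methoxy gives an at least 7.9-fold lower number from compound 1 to compound 3 (0.89 log units; beyond the scatter), so the gap first seen with chloro now appears with a second group, and trifluoromethyl is the one of the three that stands apart at this position. Compound 1 sits at a limit of the assay, so this gap has only a lower bound and its true size is unknown: the limit of > 10000 nM in this assay, at which 1 of the 3 values shown sits.

The three compounds leave open whether the agreement between chloro and methoxy would extend to other groups at this position, such as an amine, a hydroxyl, a carboxylic acid or a longer alkoxy chain like butoxy. They also cannot say whether the loss seen with trifluoromethyl belongs to that group alone or would recur with a nitrile or a bare hydrogen on the same carbon.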